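The source may report more compounds than this note shows. Statements on the series, on what has been measured and on what is new or still open speak of the compounds shown alone.

Compound 1 `N#CC1=C(NCN2CCCC2)N(c2ccccc2)C(=O)N2CCCCC(N3CCCC3)C12` carries a (pyrrolidin-1-yl)methyl group on its amine nitrogen. In a functional assay on the whole organism (strain albino) for inhibition, with Rattus norvegicus as the target, read by paw edema, with stated times of 1 h and 2 h, at a dose of 20 mmol/kg by the intraperitoneal route (on this read-out lower numbers stand for less inhibition and higher numbers for more inhibition at the one dose given (going by the name of the read-out)), compound 1 gives 26.6%, the lowest of the two numbers measured here. Compound 2 `COC(=O)C(=O)NC1=C(C#N)C2C(N3CCCC3)CCCCN2C(=O)N1c1ccccc1` has a (methoxycarbonyl)carbonyl group in that place instead, and in this assay compound 2 gives 85.6%; the step of a number 59 percentage points higher from compound 1 to compound 2 (beyond the scatter) shows that exchanging the group on the amine nitrogen for one that carries a carbonyl moves the read-out a long way upward.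

Compound 3 `N#CC1=C(NCC(=O)N2CCCCC2)N(c2ccccc2)C(=O)N2CCCCC(N3CCCC3)C12` is the compound not yet measured. It differs from compound 1 by (piperidin-1-yl)carbonyl in place of pyrrolidin-1-yl on a saturated chain carbon bound to an amine nitrogen, so the carbon bound to the amine nitrogen is kept, and a carbonyl enters one bond further out. Among the measured compounds shown here, the only measured step that bears on this is the one from compound 1 to compound 2, which was large and upward. Compound 3 shares with compound 2 the arrival of a carbonyl near the amine nitrogen but keeps the saturated chain carbon of compound 1, so a gain is expected, though a smaller one: compound 3 is estimated at 52%, with a range from 28% to 76%, a step of a number 25.4 percentage points higher from compound 1 to compound 3 (beyond the scatter).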

Compound 3, a percentage reported as inhibition, in the whole organism at one dose (the size of the read-out at that dose, not a potency): 46.1%
For compound 3 the middle estimate is 5.9 percentage points above the measured one; the measured number falls inside the stated range.
By their numbers in this assay, from the lowest: compound 1; then compound 3; then compound 2.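

The change of pyrrolidin-1-yl to (piperidin-1-yl)carbonyl on a saturated chain carbon bound to an amine nitrogen gives a number 19.5 percentage points higher from compound 1 to compound 3 (beyond the scatter) in this assay and so shows that the read-out responds to a change made one bond further out, with that carbon kept. The second comparison, a number 39.5 percentage points lower from compound 2 to compound 3 (beyond the scatter) with ((piperidin-1-yl)carbonyl)methyl in place of (methoxycarbonyl)carbonyl on an amine nitrogen, shows that having a carbonyl somewhere in the group is not enough to reach the level of compound 2. No measurement on these compounds explains why the groups differ in this way.

Compound 3 brings in the carbonyl and the six-membered ring together, so a (pyrrolidin-1-yl)carbonyl group in the same place would be needed to separate the contribution of the carbonyl from that of the larger ring. On these data alone, it also remains open how much of the high number for compound 2 depends on the methoxy end of its (methoxycarbonyl)carbonyl group, which a carboxylic acid or a primary amide at that end could test.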